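Chloro on the phenylethenyl arm of compound 3

A few compounds are considered here, and "the series" means these few. Any claim that something is new, unique, unknown or untested is made for them only; others in the source may bear on it.

Measured in a functional assay on MIA PaCa-2 cells (Homo sapiens) for inhibition, read by MTT assay, with a stated time of 48 h, tested at 10 uM; a lower number here means less inhibition of growth, a higher number more inhibition of growth at the concentration tested:
compound 1 `Cc1cc(=O)c2c(O)c(CN3CCC(Cc4ccccc4)CC3)c(O)c([C@H]3CCN(C)C[C@H]3O)c2o1`: 18%
compound 2 `CCCCCCCCCC/C=C/c1c(C)oc2c([C@H]3CCN(C)C[C@H]3O)c(O)cc(O)c2c1=O`: 4%
compound 3 `CN1CC[C@H](c2c(O)cc(O)c3c(=O)cc(/C=C/c4ccccc4)oc23)[C@H](O)C1`: 87%

Compound 3 stands highest of the three at 87%. Its gaps to compound 1 and compound 2 both lie beyond the scatter. The next compound to consider is compound 4 `CN1CC[C@H](c2c(O)cc(O)c3c(=O)cc(/C=C/c4cccc(Cl)c4)oc23)[C@H](O)C1`, which has chloro in place of hydrogen on an aromatic carbon. The change lies on an aromatic carbon of a six-membered aromatic ring of carbon only, meta to a large group, and turns 2-phenylethenyl into 2-(3-chlorophenyl)ethenyl. Going by the values given here, no pair of measured compounds differs in one place only, so the series offers no direct precedent for this change. Compound 3 at 87% leaves little room for a rise in this assay, while a large fall cannot be ruled out. The expected result is no shift beyond the scatter, and the estimated step of a number 5 percentage points lower from compound 3 to compound 4 (within the scatter) is slightly downward. For compound 4 the estimated value is 82%, with an expected range of 62% to 95%.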

Compound 4, percent growth inhibition at one concentration: 52%
For compound 4 the middle estimate is 30 percentage points above the measured one; the measured number lies below the stated range.
By their numbers in this assay, from the lowest: compound 2; then compound 1; then compound 4; then compound 3.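

Chloro in place of hydrogen on an aromatic carbon of the phenylethenyl arm gives a number 35 percentage points lower from compound 3 to compound 4 (beyond the scatter) in this assay, the first change in one place that the series can read. The arm of compound 3 is therefore not a silent region: a single added heavy atom, meta to a large group, is enough to move the read-out beyond the scatter, and compound 4 still holds 52%. Nothing available here bears on the reason for this fall.

Going by these compounds, it remains open whether the fall belongs to chloro itself or to any group on this carbon; fluoro, methoxy or an amine at the same place would separate the two. Also open, on these data alone, is whether chloro on the other carbons of that ring gives a step of similar size.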